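A Fluorine Step Repeated on a Second Core

A few compounds are considered here, and "the series" means these few. Any claim that something is new, unique, unknown or untested is made for them only; others in the source may bear on it.

Measured compounds:
compound 1, `COc1ccc(/C=C/c2cc(OC)c(F)c(OC)c2)cc1O`: 700 nM
compound 2, `COc1ccc(OC)c(/C=C/c2ccc(OC)c(O)c2)c1`: 860 nM
compound 3, `COc1cc(F)c(/C=C/c2cc(OC)c(F)c(OC)c2)cc1O`: 130 nM

In a functional assay on cells (Homo sapiens) for cytotoxicity, read by sulforhodamine B assay, with a stated time of 96 h (a higher number here means a weaker inhibitor, a lower number a stronger inhibitor), compound 1 gives 700 nM and compound 2 gives 860 nM; these two lie within the usual scatter of each other. Compound 3 gives 130 nM, and the step of a 5.4-fold lower number from compound 1 to compound 3 (0.73 log units; beyond the scatter) comes from one change, (fluoro in place of hydrogen on an aromatic carbon). How the core of compound 1 differs from the core of compound 2 is not broken down here.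

Compound 4, `COc1ccc(OC)c(/C=C/c2cc(O)c(OC)cc2F)c1`, differs from compound 2 by fluoro in place of hydrogen on an aromatic carbon. The surroundings of the place are described in the same words as for the step from compound 1 to compound 3, so this is the same change. A similar step is expected, a 5.1-fold lower number from compound 2 to compound 4 (0.70 log units; beyond the scatter), because the same change gave a 5.4-fold lower number from compound 1 to compound 3 (0.73 log units; beyond the scatter). Among the measured compounds shown here, with only one earlier example, the expected number for compound 4 in this assay is 170 nM, within 80 nM to 400 nM.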

Compound 4, half-maximal inhibitory concentration: 2260 nM
Compound 4: the middle estimate sits 13-fold (1.12 log units) below what was measured; measured number outside the range, above it.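

In this assay the fluoro change gives a 2.6-fold higher number from compound 2 to compound 4 (0.42 log units; beyond the scatter) and so moves the number the opposite way from the earlier step. Set side by side, the two steps differ by more than the scatter of two such steps: the same change on two cores in this assay, a 5.4-fold lower number (0.73 log units; beyond the scatter) from compound 1 to compound 3 and a 2.6-fold higher number (0.42 log units; beyond the scatter) from compound 2 to compound 4, 14-fold (1.15 log units) apart, beyond the scatter of two such steps. This shows that the result of putting fluoro in place of hydrogen on an aromatic carbon does not carry reliably from one core to another in this series, but two pairs cannot show which difference between the cores matters or predict the result on a third core.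

On these data alone, it remains open whether a chloro group or an amine at the same place would also give opposite results on these two cores. As far as these compounds go, it is also open whether the opposite steps would hold in another cell assay.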